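A few compounds are considered here, and "the series" means these few. Any claim that something is new, unique, unknown or untested is made for them only; others in the source may bear on it.

Working notes on the series.

Compound 1 `COc1cc2c(Oc3ccc(NC(=O)c4cc(-c5ccc(C(F)(F)F)cc5)ccn4)cc3F)ccnc2cc1OCCCN1CCCCC1` is the anchor; in a functional assay on HT-29 cells (Homo sapiens) for cytotoxicity, read by MTT assay, with a stated time of 72 h (a higher number here means a weaker inhibitor, a lower number a stronger inhibitor), compound 1 gives 230 nM. Compound 2 `COc1ccc(-c2ccnc(C(=O)Nc3ccc(Oc4ccnc5cc(OCCCN6CCCCC6)c(OC)cc45)c(F)c3)c2)cc1` differs from it by methoxy in place of trifluoromethyl on an aromatic carbon, and in this assay compound 2 gives 690 nM; the step of a 3.0-fold higher number from compound 1 to compound 2 (0.48 log units; beyond the scatter). Compound 3 `COc1cc2c(Oc3ccc(NC(=O)c4cc(-c5ccc(C(F)(F)F)cc5)ccn4)cc3F)ccnc2cc1OCCCN1CCCC1` differs from compound 1 by pyrrolidin-1-yl in place of piperidin-1-yl on a saturated chain carbon, three bonds along the chain from an oxygen on an aromatic ring, and in this assay compound 3 gives 720 nM; the step of a 3.1-fold higher number from compound 1 to compound 3 (0.50 log units; beyond the scatter). The values of compound 2 and compound 3 lie within the scatter of each other.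

Compound 4 `COc1ccc(-c2ccnc(C(=O)Nc3ccc(Oc4ccnc5cc(OCCCN6CCCC6)c(OC)cc45)c(F)c3)c2)cc1` is not yet measured. It differs from compound 3 by methoxy in place of trifluoromethyl on an aromatic carbon, the same change already made from compound 1 to compound 2, on a core that differs by the pyrrolidin-1-yl in place of piperidin-1-yl noted above. The place of the change is described identically in both pairs, so the change is taken as the same.

Because the earlier step of a 3.0-fold higher number from compound 1 to compound 2 (0.48 log units; beyond the scatter) was modest and beyond the scatter, a step of similar size is expected from compound 3 to compound 4, that is a 2.9-fold higher number from compound 3 to compound 4 (0.46 log units; beyond the scatter). On that basis, in this assay compound 4 is estimated at 2100 nM, with a plausible range from 900 nM to 5000 nM.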

Compound 4, half-maximal inhibitory concentration: 350 nM
Estimate against measurement, compound 4: 6.0-fold (0.78 log units) above; measured number outside the range, below it.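

In this assay, methoxy in place of trifluoromethyl does not carry over from the core of compound 1 to the core of compound 3: the new step, a 2.1-fold lower number from compound 3 to compound 4 (0.31 log units; beyond the scatter), runs against the earlier one, and the two differ: the same change on two cores in this assay, a 3.0-fold higher number (0.48 log units; beyond the scatter) from compound 1 to compound 2 and a 2.1-fold lower number (0.31 log units; beyond the scatter) from compound 3 to compound 4, 6.2-fold (0.79 log units) apart, beyond the scatter of two such steps

Read the other way, pyrrolidin-1-yl in place of piperidin-1-yl gives a 2.0-fold lower number from compound 2 to compound 4 (0.29 log units; within the scatter), which lies within the scatter, so this change also depends on the core that carries it: the same change on two cores in this assay, a 3.1-fold higher number (0.50 log units; beyond the scatter) from compound 1 to compound 3 and a 2.0-fold lower number (0.29 log units; within the scatter) from compound 2 to compound 4, 6.2-fold (0.79 log units) apart, beyond the scatter of two such steps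

This shows that the two changes do not combine independently across these compounds, but it rests on a single set of four compounds and does not show why the steps differ or how either change behaves on any other core.

The compounds shown leave open whether a chlorine or a plain hydrogen in the place of the trifluoromethyl would follow the same reversal. They also leave open whether a morpholine or a dimethylamino group at the end of the chain would behave like piperidin-1-yl or like pyrrolidin-1-yl.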